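From nitro to iodo on the aromatic ring

The source may hold more compounds than are shown below. What is called first, only, known or untested is meant among the compounds shown, and "the series" means these compounds.

- Compound 1 `C=C1CC[C@H]2C(C)(C)CCC[C@]2(C)[C@H]1CCC(C)CC(=O)O`: > 200000 nM, a limit
- Compound 2 `C=C1CC[C@H]2C(C)(C)CCC[C@]2(C)[C@H]1CCC(C)CC(=O)OC`: > 200000 nM, a limit
- Compound 3 `CC(CC[C@H]1/C(=C/c2ccc([N+](=O)[O-])cc2)CC[C@H]2C(C)(C)CCC[C@]12C)CC(=O)O`: 124000 nM

These results come from a functional assay on MCF7 cells (Homo sapiens) for cytotoxicity, read by MTT assay, with a stated time of 72 h; a lower number here means a stronger inhibitor, a higher number a weaker inhibitor. Within the data shown here, compound 3 holds the only actual number, as the other two results are limits. Compound 4 `CC(CC[C@H]1/C(=C/c2ccc(I)cc2)CC[C@H]2C(C)(C)CCC[C@]12C)CC(=O)O` differs from compound 3 by one change: iodo in place of nitro on an aromatic carbon.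

Among the measured compounds shown here, the one measured step, a step that the two limits leave unreadable from compound 1 to compound 2, touches no aromatic carbon and cannot be read, so it does not bear on this change. The other guide is the limit of > 200000 nM in this assay, at which 2 of the 3 values shown sit. With compound 3 at 124000 nM as the sole anchor, no shift beyond the scatter can be expected. The expected step is a 1.2-fold lower number from compound 3 to compound 4 (0.09 log units; within the scatter). For compound 4 the estimated value is 100000 nM, with an expected range of 40000 nM to 200000 nM.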

Compound 4, half-maximal inhibitory concentration: 50000 nM
For compound 4 the middle estimate is 2.0-fold (0.30 log units) above the measured one, within the range that was stated.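

In this assay, among these compounds, iodo in place of nitro on this aromatic carbon gives a 2.5-fold lower number from compound 3 to compound 4 (0.39 log units; beyond the scatter), the first readable step, so the group at this place can shift the read-out beyond the scatter. Even so, compound 4 remains a weak inhibitor, with the scale's limit still in view: the limit of > 200000 nM in this assay, at which 2 of the 4 values shown sit.

On these data alone, whether this step is particular to iodo remains open. A bromo, methoxy or amine group at this place would show whether other groups also lower the number.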